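A few compounds are considered here, and "the series" means these few. Any claim that something is new, unique, unknown or untested is made for them only; others in the source may bear on it.

Measured in a physicochemical assay for lipophilicity, measured as octanol-water partition; a higher number here means a more lipophilic compound, a lower number a more polar compound:
compound 1, `Cc1cc(Cl)cc(C)c1OCC(C)O`, 3.52
compound 2, `CC(O)COc1ccc(Cl)cc1`, 2.16
compound 3, `OCCCOc1ccc(Cl)cc1`, 2.36

In this assay compound 1 stands highest of the three, beyond the scatter from both compound 3 and compound 2. Compound 2 and compound 3 share a core; the change between them is 2-hydroxyethyl in place of 1-hydroxyethyl on a saturated chain carbon bound to an oxygen on an aromatic ring and it gave a number 0.20 log units higher from compound 2 to compound 3 (within the scatter). The difference between the core of compound 1 and the core of compound 2 is not broken down here. Compound 4, `Cc1cc(Cl)cc(C)c1OCCCO`, has not been measured yet; it differs from compound 1 by 2-hydroxyethyl in place of 1-hydroxyethyl on a saturated chain carbon bound to an oxygen on an aromatic ring, the same change seen once already among these compounds. Because the step of a number 0.20 log units higher from compound 2 to compound 3 (within the scatter) stayed within the scatter, the change is expected to give a step of about the same size again, a number 0.20 log units higher from compound 1 to compound 4 (within the scatter). Compound 4 is therefore estimated at 3.72, expected between 3.35 and 4.1.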

Compound 4, partition coefficient: 3.72
Compound 4: the middle estimate sits on the measured number at the digits printed, within the range that was stated.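

In this assay the change from 1-hydroxyethyl to 2-hydroxyethyl gave a number 0.20 log units higher from compound 1 to compound 4 (within the scatter) on the core of compound 1 and a number 0.20 log units higher from compound 2 to compound 3 (within the scatter) on the other core, so the step read the same on both. Going by these compounds alone, since each step lies within the scatter, this shows only that the change carried across these two cores without a step distinguishable from repeat measurement, and it does not show that the change itself raises the number. Nothing given here bears on why the two steps agree.

The compounds shown leave open whether the same result would hold on any further core. They also leave open what would follow with an amine in place of the hydroxy group, or with a longer chain.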